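Stripping the diol side chain from a thioether-linked core

A few compounds are considered here, and "the series" means these few. Any claim that something is new, unique, unknown or untested is made for them only; others in the source may bear on it.

Three compounds share one core and differ only in the group attached to a sulfur. Compound 1 `CC(C)c1n[nH]c2c(NCc3ccc(-c4ccccn4)cc3)nc(SCC(O)CO)nc12` carries a 2,3-dihydroxypropyl group there, and in a functional assay on HT cells (Homo sapiens) for antiproliferative activity, read by fluorescence, with a stated time of 72 h (on this read-out higher numbers stand for weaker inhibition of growth and lower numbers for stronger inhibition of growth), compound 1 gives 21 nM, the lowest number of the three. Compound 2 `CC(C)c1n[nH]c2c(NCc3ccc(-c4ccccn4)cc3)nc(SC3CCCCC3O)nc12` carries a 2-hydroxycyclohexyl group and gives 636 nM; compound 3 `C=CCSc1nc(NCc2ccc(-c3ccccn3)cc2)c2[nH]nc(C(C)C)c2n1` carries an allyl group and gives 1010 nM. Replacing the diol chain cost potency in both cases: a 30-fold higher number from compound 1 to compound 2 (1.48 log units; beyond the scatter) and a 48-fold higher number from compound 1 to compound 3 (1.68 log units; beyond the scatter). Between the two replacements the gap is small, a 1.6-fold higher number from compound 2 to compound 3 (0.20 log units; within the scatter).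

Compound 4 `CC(C)c1n[nH]c2c(NCc3ccc(-c4ccccn4)cc3)nc(S)nc12` removes the side chain altogether, leaving a bare hydrogen on the sulfur: hydrogen in place of 2,3-dihydroxypropyl on a sulfur. For the measured compounds named here, no measured step removes the whole group, so the steps from compound 1 to compound 2 and from compound 1 to compound 3 are the closest guides. Both show that losing the two hydroxyl groups of the chain brings a large loss of growth inhibition, so a large rise in this assay is expected here too, and compound 4 is expected to follow the step of a 38-fold higher number from compound 1 to compound 4 (1.58 log units; beyond the scatter). The estimate for compound 4 is 800 nM, within a range from 150 nM to 4000 nM.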

Compound 4, concentration for 50% growth inhibition: 2760 nM
The estimate for compound 4 lay 3.5-fold (0.54 log units) below the measured number, and the stated range covers the measured number.
By their numbers in this assay, from the lowest: compound 1; then compounds 2 and 3 (each within the scatter of the next); then compound 4.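

Taking the whole side chain off the sulfur produces the widest gap in this set in this assay: a 130-fold higher number from compound 1 to compound 4 (2.12 log units; beyond the scatter). Most of that gap is already present with the allyl and 2-hydroxycyclohexyl groups. The further steps to the bare hydrogen are only modest: a 2.7-fold higher number from compound 3 to compound 4 (0.44 log units; beyond the scatter) and a 4.3-fold higher number from compound 2 to compound 4 (0.64 log units; beyond the scatter). A group on this sulfur, even one without the 2,3-dihydroxypropyl chain, therefore goes with somewhat stronger inhibition of growth than hydrogen alone, while compound 1 stands well apart from all three others.

No measurement offered here explains why these gaps arise. For the compounds shown here, still open is what in the 2,3-dihydroxypropyl group matters: a plain propyl chain, a 2-hydroxyethyl chain with only one hydroxyl group, or a 2-aminoethyl group on the same sulfur would show whether both hydroxyl groups are needed, and whether another group could take their place.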